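Halogen Swap Carried From One Ketone Core to Another

The source may hold more compounds than are shown below. What is called first, only, known or untested is meant among the compounds shown, and "the series" means these compounds.

Compound 1 `O=C1/C(=C/c2cccc(Cl)c2)CCCc2ccccc21` and compound 2 `O=C1/C(=C/c2cccc(Br)c2)CCCc2ccccc21` share one core. In a functional assay on CCRF-CEM cells (Homo sapiens) for inhibition (a lower number here means a stronger inhibitor, a higher number a weaker inhibitor), compound 1 gives 9440 nM, and compound 2 gives 8900 nM. The change between them, (bromo in place of chloro on an aromatic carbon), produced a 1.1-fold lower number from compound 1 to compound 2 (0.03 log units; within the scatter). Compound 3 `O=C1CCCCC/C1=C\c1cccc(Cl)c1` carries the same chloro substituent on a different core; the difference between the two cores is not broken down here. In this assay compound 3 gives 40500 nM, the highest of the three numbers. Compound 4 `O=C1CCCCC/C1=C\c1cccc(Br)c1` is related to compound 3 by bromo in place of chloro on an aromatic carbon, the same kind of change as that between compound 1 and compound 2, although here the place is meta to a group of 9 heavy atoms rather than meta to a large group. Because a 1.1-fold lower number from compound 1 to compound 2 (0.03 log units; within the scatter) stayed within the scatter, a similar step is expected: a 1.1-fold lower number from compound 3 to compound 4 (0.03 log units; within the scatter). On that basis compound 4 is estimated at 38000 nM in this assay.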

Compound 4, half-maximal inhibitory concentration: 137000 nM
Beside the measured number, compound 4's estimate is 3.6-fold (0.56 log units) below it; the measured number lies above the stated range.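

In this assay, bromo in place of chloro on an aromatic carbon gave a 3.4-fold higher number from compound 3 to compound 4 (0.53 log units; beyond the scatter), so the near absence of a step on the core of compound 1 did not carry over to the core of compound 3. The two cores answered this change differently: the same change on two cores in this assay, a 1.1-fold lower number (0.03 log units; within the scatter) from compound 1 to compound 2 and a 3.4-fold higher number (0.53 log units; beyond the scatter) from compound 3 to compound 4, 3.6-fold (0.55 log units) apart, beyond the scatter of two such steps. This shows that the result of the swap on one core did not predict its result on the other here, but it does not show why they differ, and two pairs set no rule for other cores.

From the compounds shown here alone, it remains open how a fluoro, a methoxy or an amine at the same place would behave on each core. Also open, going by these compounds, is which of the two outcomes the same swap would follow on any further core.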